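A few compounds are considered here, and "the series" means these few. Any claim that something is new, unique, unknown or untested is made for them only; others in the source may bear on it.

Measured so far in a functional assay for antagonist activity at melanin-concentrating hormone receptor 1 (Homo sapiens); a lower number here means a stronger inhibitor, a higher number a weaker inhibitor:
compound 1, `N#Cc1cccc([C@]23CCC(N(CCN4CC[C@@H](O)C4)C(=O)Nc4cccc(Cl)c4)CC2C3)c1`, gives 27 nM;
compound 2, `CC(C)N(CCN(C(=O)Nc1cccc([N+](=O)[O-])c1)C1CC[C@]2(c3cccc(C#N)c3)CC2C1)C(C)C`, gives 2.7 nM;
compound 3, `CC(C)N(CCN(C(=O)Nc1cccc(Br)c1)C1CC[C@]2(c3cccc(C#N)c3)CC2C1)C(C)C`, gives 5.7 nM.

Compound 3 stands second of the three numbers: compound 2 sits a step lower (a 2.1-fold higher number from compound 2 to compound 3 (0.32 log units; beyond the scatter)), and compound 1 sits further up, though compound 1 also carries a different amine on the side chain and is not a single-point neighbour of compound 3.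

Compound 4, `CC(C)N(CCN(C(=O)Nc1cccc(Cl)c1)C1CC[C@]2(c3cccc(C#N)c3)CC2C1)C(C)C`, is not yet measured. It differs from compound 3 in one place: chloro in place of bromo on an aromatic carbon. Going by the values given here, no measured step in this assay changes bromo to chloro. Among the compounds with values here, the only single-point step known here, from compound 2 to compound 3, swaps nitro for bromo and was modest in size; it says little about a halogen-for-halogen exchange. On that basis the step from compound 3 to compound 4 is expected to be small, most likely within the scatter, with no firm direction: a 1.2-fold higher number from compound 3 to compound 4 (0.09 log units; within the scatter). For compound 4 the estimated value in this assay is 7 nM, with a range from 3 nM to 16 nM.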

Compound 4, inhibition constant: 6 nM
Compound 4: the middle estimate sits 1.2-fold (0.07 log units) above what was measured, and the stated range covers the measured number.
By their numbers in this assay, from the lowest: compound 2; then compounds 3 and 4 (each within the scatter of the next); then compound 1.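

In this assay, chloro in place of bromo on this aromatic carbon gives a 1.1-fold higher number from compound 3 to compound 4 (0.02 log units; within the scatter) and so separates neither halogen from the other. Nitro keeps the lower number against chloro too, with a 2.2-fold higher number from compound 2 to compound 4 (0.35 log units; beyond the scatter) as the step, so the gap seen earlier with bromo is not particular to bromo. Going by these compounds alone, with chloro held fixed, the side chain can now be read on its own: a 4.5-fold lower number from compound 1 to compound 4 (0.65 log units; beyond the scatter) goes with diisopropylamino in place of 3-hydroxypyrrolidin-1-yl, the first single-point reading of that amine.

On these data alone, whether fluoro, methoxy or a carboxylic acid on this aromatic carbon would fall with the halogens or with nitro stays open, as does the effect of a longer chain to the amine. Nothing available gives a reason for any of these steps.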